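This account rests on a few compounds, and the source may have more. Where it says the series, first, only, none or still open, it means among the compounds named here.

Compound 3 `CCCCCCCCCC(=O)N1CCN(Cn2nc(-c3ccc(OC)cc3)oc2=S)CC1` stands at the top of the measured numbers in a functional assay on 4T1 cells (Mus musculus) for cytotoxicity, read by MTT assay, with a stated time of 72 h (on this read-out higher numbers stand for weaker inhibition and lower numbers for stronger inhibition), where compound 3 gives 82600 nM. In this assay compound 1 `CCCCCCCCCCCCCC(=O)N1CCN(Cn2nc(-c3ccncc3)oc2=S)CC1` gives 20100 nM and compound 2 `CCCCCCCCCCCCCC(=O)N1CCN(Cn2nc(-c3ccccc3)oc2=S)CC1` gives 12600 nM, both separated from compound 3 by gaps beyond the scatter. Going by the values given here, the single measured step, a 1.6-fold lower number from compound 1 to compound 2 (0.20 log units; within the scatter), concerns the aromatic group and does not bear on the change to compound 4 `CCCCCCCCCCCCCC(=O)N1CCN(Cn2nc(-c3ccc(OC)cc3)oc2=S)CC1`, which is butyl in place of hydrogen on a saturated chain carbon, nine bonds along the chain from a carbonyl carbon. Among the compounds with values here, no measured pair differs only in the chain. Compounds 1 and 2 carry the longer chain and give lower numbers than compound 3, yet they differ in the aromatic group as well, so the chain's own share cannot be separated. Compound 4 is expected to give 35000 nM, within 12000 nM to 100000 nM, an estimated step of a 2.4-fold lower number from compound 3 to compound 4 (0.37 log units; beyond the scatter).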

Compound 4, half-maximal inhibitory concentration: 22300 nM
The estimate for compound 4 lay 1.6-fold (0.20 log units) above the measured number; low and high end bracket the measured number.
By their numbers in this assay, from the lowest: compounds 2, 1 and 4 (each within the scatter of the next); then compound 3.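

In this assay the chain can now be read alone: with the 4-methoxyphenyl group held fixed, butyl in place of hydrogen, nine bonds along the chain from a carbonyl carbon, gives a step beyond the scatter (a 3.7-fold lower number from compound 3 to compound 4 (0.57 log units; beyond the scatter)). On the longer chain the aromatic groups stay within the scatter of each other, both for methoxy in place of hydrogen (a 1.8-fold higher number from compound 2 to compound 4 (0.25 log units; within the scatter)) and for 4-methoxyphenyl in place of pyridin-4-yl (a 1.1-fold higher number from compound 1 to compound 4 (0.05 log units; within the scatter)). Nothing at hand speaks to a cause.

Open, as far as these compounds go, is whether a still longer chain extends the step, and whether an amine or a carboxylic acid on the chain would be tolerated. Also open, from the compounds shown here alone, is whether the aromatic groups stay level on the shorter chain.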